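Pyridine Swap on Two Cores in a Liver-Cell Toxicity Assay

The source may report more compounds than this note shows. Statements on the series, on what has been measured and on what is new or still open speak of the compounds shown alone.

Compound 1 `O=C1CCCC2=C1C(c1ccc(F)cc1Cl)N=C(c1cccnc1)N2`: 82800 nM
Compound 2 `CC1(C)CC(=O)C2=C(C1)NC(c1cccnc1)=NC2c1ccc(F)cc1Cl`: 624000 nM
Compound 3 `O=C1CCCC2=C1C(c1ccc(F)cc1Cl)N=C(c1ccncc1)N2`: 142000 nM

All three were tested in an ADME assay on HepG2 2.2.15 cells (Homo sapiens) for cytotoxicity; on this read-out lower numbers stand for stronger inhibition and higher numbers for weaker inhibition. Compound 1 and compound 3 share one core, while compound 2 has another; the difference between the two cores is not broken down here. In this assay compound 2 gives the highest number of the three. From compound 1 to compound 3 the change is pyridin-4-yl in place of pyridin-3-yl on a carbon with a double bond to nitrogen, and the step was a 1.7-fold higher number from compound 1 to compound 3 (0.23 log units; within the scatter).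

Compound 4 `CC1(C)CC(=O)C2=C(C1)NC(c1ccncc1)=NC2c1ccc(F)cc1Cl` has not been measured. It differs from compound 2 by pyridin-4-yl in place of pyridin-3-yl on a carbon with a double bond to nitrogen, the same change at the same place. Because the step of a 1.7-fold higher number from compound 1 to compound 3 (0.23 log units; within the scatter) was within the scatter, a step of about the same size is expected, namely a 1.4-fold higher number from compound 2 to compound 4 (0.16 log units; within the scatter). The estimate for compound 4 in this assay is 900000 nM, expected to lie between 400000 nM and 2000000 nM.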

Compound 4, half-maximal inhibitory concentration: 135000 nM
Compound 4: the middle estimate sits 6.7-fold (0.82 log units) above what was measured, outside the stated range (below it).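

In this assay, the swap of pyridin-3-yl for pyridin-4-yl gave a 4.6-fold lower number from compound 2 to compound 4 (0.66 log units; beyond the scatter), and this does not agree with the earlier result for the same swap: the same change on two cores in this assay, a 1.7-fold higher number (0.23 log units; within the scatter) from compound 1 to compound 3 and a 4.6-fold lower number (0.66 log units; beyond the scatter) from compound 2 to compound 4, 7.9-fold (0.90 log units) apart, beyond the scatter of two such steps. In this series, then, the step measured on the core of compound 1 could not be carried over as a fixed step to the core of compound 2. Going by these compounds alone, with only one pair on each core, these results do not show which part of the cores matters or how the difference arises.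

From the compounds shown here alone, it remains open how a phenyl ring or pyridin-2-yl would behave at this place on each core. Whether a third core would follow either pair is also unknown.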